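The compounds below may be only part of what the source reports. "The series", "measured", "known", "first", "only" and "open" are said of these compounds alone.

Working notes on the series. Compound 1 `COc1ccc2c(/C=C/C(=O)c3cc(OC)c(OC)c([N+](=O)[O-])c3)c[nH]c2c1` is the reference point: in a functional assay on HCT-8 cells (Homo sapiens) for antiproliferative activity, read by MTT assay, with a stated time of 48 h (on this read-out higher numbers stand for weaker inhibition and lower numbers for stronger inhibition), compound 1 gives 982 nM. Compound 2 `COc1cc(C(=O)/C=C/c2c[nH]c3ccccc23)cc([N+](=O)[O-])c1OC` is the matched partner in which one group is removed; in this assay compound 2 gives 1390 nM. The change between them is hydrogen in place of methoxy on an aromatic carbon and the step it made is a 1.4-fold higher number from compound 1 to compound 2 (0.15 log units; within the scatter), so on this pair the removal made no difference that can be separated from repeat-to-repeat noise.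

Compound 3 `COc1ccc2c(/C=C/C(=O)c3cc(OC)c(OC)c(SC)c3)cn(C)c2c1` stands on a different core; in this assay compound 3 gives 157 nM, the lowest of the three numbers. The difference between the core of compound 3 and the core of compound 1 is not broken down here.

Compound 4 `COc1cc(C(=O)/C=C/c2cn(C)c3ccccc23)cc(SC)c1OC` has not yet been measured in this assay. It differs from compound 3 by hydrogen in place of methoxy on an aromatic carbon, the same change as that from compound 1 to compound 2, at the same kind of place. The expected step is a 1.4-fold higher number from compound 3 to compound 4 (0.15 log units; within the scatter), set beside a 1.4-fold higher number from compound 1 to compound 2 (0.15 log units; within the scatter), because the only measured occurrence of this change, a 1.4-fold higher number from compound 1 to compound 2 (0.15 log units; within the scatter), stayed within the scatter. Compound 4 is therefore estimated at 220 nM, expected to fall between 90 nM and 550 nM.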

Compound 4, half-maximal inhibitory concentration: 210 nM
For compound 4 the middle estimate is 1.0-fold (0.02 log units) above the measured one; low and high end bracket the measured number.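

In this assay, hydrogen in place of methoxy on an aromatic carbon gave a 1.3-fold higher number from compound 3 to compound 4 (0.13 log units; within the scatter), so on this second pair as well the change cannot be separated from repeat-to-repeat noise. Set beside the first pair, the change carries over from one core to the other with no difference that stands out from the scatter: the same change on two cores in this assay, a 1.4-fold higher number (0.15 log units; within the scatter) from compound 1 to compound 2 and a 1.3-fold higher number (0.13 log units; within the scatter) from compound 3 to compound 4, 1.1-fold (0.02 log units) apart, within the scatter of two such steps

Going by these compounds alone, this supports treating the removal of this methoxy as a change of no measurable size on these two cores, but it rests on only two pairs and a single cell line, and it does not show that the same would hold on any other core or that the methoxy is without effect under other conditions.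

Among the compounds shown, this place carries only methoxy or hydrogen, so the reading for a hydroxyl, an amine or a longer alkoxy chain there remains open. Also open, from the compounds shown here alone, is whether the change would stay this small in other cell lines.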